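This account rests on a few compounds, and the source may have more. Where it says the series, first, only, none or still open, it means among the compounds named here.

Working notes on the series. Three compounds share one core and differ only in the group on the amide-type nitrogen at the far end of the chain. Compound 1 `O=C(CCC(=O)OCCCCCCSc1ccc([N+](=O)[O-])c2nonc12)Nc1cccc(Cl)c1` gives 1100 nM in an assay on isolated protein for inhibition of glutathione S-transferase Mu 2 (Homo sapiens), with a stated time of 10 min; a lower number here means a stronger inhibitor, a higher number a weaker inhibitor. Compound 2 `COc1ccc(NC(=O)CCC(=O)OCCCCCCSc2ccc([N+](=O)[O-])c3nonc23)cc1OC` gives 360 nM, and compound 3 `O=C(CCC(=O)OCCCCCCSc1ccc([N+](=O)[O-])c2nonc12)NCCN1CCCC1` gives 200 nM. Compound 3 has the lowest number of the three: the step from compound 1 is a 5.5-fold lower number from compound 1 to compound 3 (0.74 log units; beyond the scatter), while the other step ending at it is a 1.8-fold lower number from compound 2 to compound 3 (0.26 log units; within the scatter), so compound 2 and compound 3 cannot be ordered. The step of a 3.1-fold lower number from compound 1 to compound 2 (0.49 log units; beyond the scatter) is the other measured move in this position.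

Compound 4 `O=C(CCC(=O)N1CCCCC1)OCCCCCCSc1ccc([N+](=O)[O-])c2nonc12` is not yet measured. Its change from compound 3 is piperidin-1-yl in place of (2-(pyrrolidin-1-yl)ethyl)amino on a carbonyl carbon. For the measured compounds named here, all three measured steps bear on it, since each swaps the group on the same carbonyl carbon, and none moved the number by more than a modest amount; none, however, removed the amide hydrogen, so that part of the change has no precedent here. Expectation is therefore a step of a 2.3-fold higher number from compound 3 to compound 4 (0.35 log units; beyond the scatter) in this assay that stays near or within the scatter, most likely a somewhat higher number. Compound 4 is estimated at 450 nM, within 150 nM to 1300 nM.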

Compound 4, half-maximal inhibitory concentration: 110 nM
The estimate for compound 4 lay 4.1-fold (0.61 log units) above the measured number; measured number below the stated range.
By their numbers in this assay, from the lowest: compounds 4, 3 and 2 (each within the scatter of the next, the first and the last beyond it); then compound 1.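

In this assay, for the compounds shown here, the swap to piperidin-1-yl on a carbonyl carbon gives a 1.8-fold lower number from compound 3 to compound 4 (0.26 log units; within the scatter) and compound 3 and compound 4 cannot be ordered, so the first change here to remove the amide hydrogen shows no measurable loss. The same group stands clear of both aromatic amides, with a 3.3-fold lower number from compound 2 to compound 4 (0.51 log units; beyond the scatter) and a 10-fold lower number from compound 1 to compound 4 (1.00 log units; beyond the scatter) so a saturated ring on this nitrogen does at least as well as either aromatic group in the set. Nothing in hand accounts for these steps.

This change alters the ring, the size of the group and the amide hydrogen all at once, and the compounds shown do not separate these: pyrrolidin-1-yl, morpholin-4-yl or dimethylamino on the same carbonyl carbon, or a methyl on the amide nitrogen of compound 3, would each bear on that question. Also open, on these data alone, is whether piperidin-1-yl keeps its standing with a shorter or longer chain, or with an amide in place of the ester that all four compounds share.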